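Amine Substituent Variation on a Bradykinin B1 Antagonist Series

A few compounds are considered here, and "the series" means these few. Any claim that something is new, unique, unknown or untested is made for them only; others in the source may bear on it.

Of the compounds shown here, two have been measured so far. Compound 1 `CC(C)(C)NCc1ccc2c(c1)CCC[C@H]2NC(=O)C[C@@H]1CCCCN1S(=O)(=O)c1cccc(Cl)c1` gives 73 nM in a functional assay for inhibition of B1 bradykinin receptor (Homo sapiens), read by calcium flux; a higher number here means a weaker inhibitor, a lower number a stronger inhibitor. Compound 2 `CC(C)(C)CNCc1ccc2c(c1)CCC[C@H]2NC(=O)C[C@@H]1CCCCN1S(=O)(=O)c1cccc(C(F)(F)F)c1` gives 230 nM in this assay, the higher of the two numbers, and the gap to compound 1 lies beyond the scatter. Compound 3 `O=C(C[C@@H]1CCCCN1S(=O)(=O)c1cccc(C(F)(F)F)c1)N[C@@H]1CCCc2cc(CNCC3CC3)ccc21` carries cyclopropyl in place of tert-butyl on a saturated chain carbon bound to an amine nitrogen. Going by the values given here, no measured pair shows this change, so the expected step of a 1.2-fold lower number from compound 2 to compound 3 (0.06 log units; within the scatter) is small, with no clear direction beyond the scatter. Compound 3 is therefore expected to give about 200 nM, within a range from 70 nM to 600 nM.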

Compound 3, half-maximal inhibitory concentration: 31 nM
Beside the measured number, compound 3's estimate is 6.5-fold (0.81 log units) above it; the whole stated range lies above it.
By their numbers in this assay, from the lowest: compound 3; then compound 1; then compound 2.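

On the saturated chain carbon bound to an amine nitrogen, cyclopropyl in place of tert-butyl gives a 7.4-fold lower number from compound 2 to compound 3 (0.87 log units; beyond the scatter) in this assay and so shows that this position responds to the group it carries. Going by these compounds alone, it is the first step that differs in one place, and it stays beyond the scatter even though only one heavy atom is lost and a three-membered ring enters. Nothing available explains the step. As far as these compounds go, whether a cyclobutyl or an isopropyl group at this place would behave like cyclopropyl remains open. Also open, from the compounds shown here alone, is whether the step would hold with the chlorine of compound 1 in place of trifluoromethyl.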